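This account rests on a few compounds, and the source may have more. Where it says the series, first, only, none or still open, it means among the compounds named here.

Values in an ADME assay on Vero cells (Chlorocebus sabaeus) for cytotoxicity, read by MTT assay (a lower number here means a stronger inhibitor, a higher number a weaker inhibitor), so far
- compound 1 `CN(Cc1ccccc1)c1cc(C(=O)Nc2ccccc2)ncn1` gives 314000 nM
- compound 2 `CCN(Cc1ccc(Cl)cc1)c1cc(C(=O)Nc2ccccc2)ncn1` gives 272000 nM
- compound 3 `CN(Cc1ccc(F)cc1)c1cc(C(=O)Nc2ccccc2)ncn1` gives 297000 nM

Compound 3 at 297000 nM lies within the scatter of both compound 1 and compound 2, so these three values give no order. The next compound is compound 4 `CN(Cc1ccc(Cl)cc1)c1cc(C(=O)Nc2ccccc2)ncn1`, which differs from compound 3 by chloro in place of fluoro on an aromatic carbon with chloro in place of fluoro on an aromatic carbon, para to a large group. Within the data shown here, one measured step bears directly on this place: a 1.1-fold lower number from compound 1 to compound 3 (0.02 log units; within the scatter) for fluoro in place of hydrogen on an aromatic carbon, and it stays within the scatter. Among the measured compounds shown here, no measured compound stands apart from the others, although three values are a thin basis. No change beyond the scatter is therefore expected in this assay and the estimated step is a 1.0-fold lower number from compound 3 to compound 4 (0.02 log units; within the scatter) with no firm direction. For compound 4 the estimated value is 285000 nM with an expected range from 200000 nM to 400000 nM for a repeat measurement.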

Compound 4, half-maximal inhibitory concentration: 207000 nM
Estimate against measurement, compound 4: 1.4-fold (0.14 log units) above; low and high end bracket the measured number.
By their numbers in this assay, from the lowest: compounds 4, 2, 3 and 1 (each within the scatter of the next).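

Read in this assay the change from 4-fluorophenyl to 4-chlorophenyl gives a step within the scatter (a 1.4-fold lower number from compound 3 to compound 4 (0.16 log units; within the scatter)), and chloro in place of hydrogen on the same aromatic carbon, para to a large group, also stays within it (a 1.5-fold lower number from compound 1 to compound 4 (0.18 log units; within the scatter)). This position has now taken two halogens without a step beyond the scatter, where fluoro alone had been tested before. With 4-chlorobenzyl held constant, methyl against the ethyl of compound 2 also stays within the scatter (a 1.3-fold lower number from compound 2 to compound 4 (0.12 log units; within the scatter)), and no measured evidence bears on these values.

Open, going by these compounds, is whether a nitrile, a methoxy group or a carboxylic acid on this aromatic carbon would move the number beyond the scatter. Also open, on these data alone, is whether an amine or a longer chain on the nitrogen of the shared core would do so.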